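This account rests on a few compounds, and the source may have more. Where it says the series, first, only, none or still open, it means among the compounds named here.

Measured so far, in a functional assay on HEL cells (Homo sapiens) for cytotoxicity, read by microscopy; a higher number here means that more compound is tolerated, a lower number that less compound is tolerated:
Compound 1 `CCOC(=O)NC(=O)NC1=CS(=O)(=O)O[C@@]12[C@@H](CO[Si](C)(C)C(C)(C)C)O[C@@H](n1cc(C)c(=O)n(C)c1=O)[C@@H]2O[Si](C)(C)C(C)(C)C` gives 16000 nM.
Compound 2 `CC(=O)NC1=CS(=O)(=O)O[C@@]12[C@@H](CO[Si](C)(C)C(C)(C)C)O[C@@H](n1cc(C)c(=O)n(C)c1=O)[C@@H]2O[Si](C)(C)C(C)(C)C` gives >= 80000 nM, a limit of the assay (the limit of >= 80000 nM in this assay, at which 1 of the 3 values shown sits).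
Compound 3 `Cc1cn([C@@H]2O[C@H](CO[Si](C)(C)C(C)(C)C)[C@@]3(OS(=O)(=O)C=C3NC(N)=O)[C@H]2O[Si](C)(C)C(C)(C)C)c(=O)n(C)c1=O` gives 16000 nM.

Compound 3 sits level with compound 1: no change at the digits printed from compound 1 to compound 3 (within the scatter). Between compound 1 and compound 2 the reading is an at least 5.0-fold higher number from compound 1 to compound 2 (0.69 log units; beyond the scatter), and between compound 2 and compound 3 it is an at least 5.0-fold lower number from compound 2 to compound 3 (0.69 log units; beyond the scatter).

Compound 4 `Cc1cn([C@@H]2O[C@H](CO[Si](C)(C)C(C)(C)C)[C@@]3(OS(=O)(=O)C=C3NCC(=O)OCc3ccccc3)[C@H]2O[Si](C)(C)C(C)(C)C)c(=O)n(C)c1=O` differs from compound 3 as follows: (benzyloxycarbonyl)methyl in place of carbamoyl on an amine nitrogen. None of the measured steps matches this change; the only shown steps vary the substituent on the carbonyl carbon or the amide-type nitrogen, while here the carbamoyl is removed altogether. In this assay compound 4 is therefore expected to give about 16000 nM, between 5000 nM and 50000 nM, meaning an estimated step of no change at the digits printed from compound 3 to compound 4 (within the scatter).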

Compound 4, minimum cytotoxic concentration: >= 400000 nM
Compound 4: no number, only a limit; the forecaster's own chance of this, stated with the estimate: 20%; at least 25-fold (1.39 log units) between middle value and limit.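

In this assay, among the compounds shown here, compound 4 gives >= 400000 nM, a limit of the assay. (Benzyloxycarbonyl)methyl is the first group on this amine nitrogen not attached through a carbonyl, and it gives an at least 25-fold higher number from compound 3 to compound 4 (1.39 log units; beyond the scatter) and an at least 25-fold higher number from compound 1 to compound 4 (1.39 log units; beyond the scatter). Compound 2 and compound 4 both stand at limits, so the step between them cannot be read.

Whether the benzyl ester or the loss of the carbonyl-attached group accounts for the step remains open. A carboxylic acid in place of the benzyl ester, or a plain ethyl on this amine nitrogen, would separate the two.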